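From fluoro to chloro on compound 3

The compounds below may be only part of what the source reports. "The series", "measured", "known", "first", "only" and "open" are said of these compounds alone.

In a functional assay on HeLa cells (Homo sapiens) for antiproliferative activity, read by MTT assay, with a stated time of 48 h (a higher number here means a weaker inhibitor, a lower number a stronger inhibitor), compound 1 (`COc1ccc2nc(NC(c3cn(-c4ccccc4)nc3-c3ccc(F)cc3)c3c(O)ccc4ccccc34)sc2c1`) gives 4630 nM and compound 2 (`COc1ccc(-c2nn(-c3ccccc3)cc2C(Nc2nc3ccc(OC)cc3s2)c2c(O)ccc3ccccc23)cc1`) gives 9240 nM while compound 3 (`Oc1ccc2ccccc2c1C(Nc1nc2ccc(Cl)cc2s1)c1cn(-c2ccccc2)nc1-c1ccc(F)cc1`) stands highest of the three at 30100 nM as the weakest inhibitor. Compound 4 (`Oc1ccc2ccccc2c1C(Nc1nc2ccc(Cl)cc2s1)c1cn(-c2ccccc2)nc1-c1ccc(Cl)cc1`) has not yet been measured. It carries chloro in place of fluoro on an aromatic carbon, para to a large group (chloro in place of fluoro on an aromatic carbon) so that 4-fluorophenyl becomes 4-chlorophenyl. Among the measured compounds shown here, only one measured change touches that place (a 2.0-fold higher number from compound 1 to compound 2 (0.30 log units; within the scatter)) and it brought in methoxy, not chloro. The other measured change (a 6.5-fold higher number from compound 1 to compound 3 (0.81 log units; beyond the scatter)) lies elsewhere on the molecule. No step beyond the scatter is therefore expected (a 1.2-fold lower number from compound 3 to compound 4 (0.08 log units; within the scatter)) in this assay for this swap. Compound 4 is expected near 25000 nM with 10000 nM to 60000 nM as the likely range.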

Compound 4, half-maximal inhibitory concentration: 36800 nM
Compound 4: the middle estimate sits 1.5-fold (0.17 log units) below what was measured, and the stated range covers the measured number.
By their numbers in this assay, from the lowest: compounds 1 and 2 (each within the scatter of the next); then compounds 3 and 4 (each within the scatter of the next).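

In this assay, chloro in place of fluoro gives a 1.2-fold higher number from compound 3 to compound 4 (0.09 log units; within the scatter), so the two halogens cannot be told apart at this position on the core of compound 3. The earlier step at this place brought in methoxy and was read on a core carrying another methoxy group, whereas this one compares two halogens on the chloro-bearing core. Nothing available explains this result. Still open, going by these compounds, is how an amine or a carboxylic acid would fare at this position. Also open, on these data alone, is whether the same swap reads alike on compound 1, which carries methoxy where compound 3 carries chloro.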